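Benzyl Removal on Pyrimidinedione Side Chains: Antiproliferative Readouts

The source may report more compounds than this note shows. Statements on the series, on what has been measured and on what is new or still open speak of the compounds shown alone.

Compound 1 `C[Si](C)(C)CCOCn1c(CC(O)COCc2ccccc2)cc(=O)[nH]c1=O` gives > 100000 nM.
Compound 2 `C[Si](C)(C)CCOCn1c(CC(O)CO)cc(=O)[nH]c1=O` gives > 100000 nM.
Compound 3 `COCn1c(CC(O)COCc2ccccc2)c(C)c(=O)[nH]c1=O` gives > 100000 nM.

All three measured compounds were tested in a functional assay on HepG2 cells (Homo sapiens) for antiproliferative activity, read by MTT assay, with a stated time of 72 h; on this read-out lower numbers stand for stronger inhibition and higher numbers for weaker inhibition. For compound 1 the value > 100000 nM is a limit of the assay rather than a number. For compound 2 the value > 100000 nM is likewise a limit. For compound 3 the value > 100000 nM is again a limit. The change from compound 1 to compound 2 is hydrogen in place of benzyl on an oxygen on a saturated carbon, and the step it made, a step that the two limits leave unreadable from compound 1 to compound 2, cannot be read in size, since both values sit at the limit of > 100000 nM in this assay, at which 3 of the 3 values shown sit. How the core of compound 3 differs from the core of compound 1 is not broken down here.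

Compound 4 `COCn1c(CC(O)CO)c(C)c(=O)[nH]c1=O` has not yet been measured. It differs from compound 3 by hydrogen in place of benzyl on an oxygen on a saturated carbon, the same change, at the same place, that takes compound 1 to compound 2. Given that compound 3 sits at a limit, and that the one earlier example of this change left compound 2 at a limit as well, compound 4 is expected to remain at the limit of this assay, with the expected step that the limit leaves unreadable from compound 3 to compound 4. The estimate for compound 4 is therefore 150000 nM, with a range from 100000 nM to 300000 nM, and most likely the assay will again report only a limit.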

Compound 4, half-maximal inhibitory concentration: > 100000 nM
Compound 4 was reported as a limit (the forecaster's own chance of this, stated with the estimate: 90%); the middle value is on the limit's open side.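

Within the data shown here, compound 3 and compound 4 are both reported only as limits, not as numbers, so removing the benzyl group gives no step whose size can be read in this assay, and the whole set shows the same picture: the limit of > 100000 nM in this assay, at which 4 of the 4 values shown sit. The compounds shown leave open whether changing benzyloxy to hydroxy alters antiproliferative activity at all, and what change would bring a measurable value.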